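The source may report more compounds than this note shows. Statements on the series, on what has been measured and on what is new or still open speak of the compounds shown alone.

Notes on the series in an ADME assay on THP-1 cells (Homo sapiens) for cytotoxicity, read by flow cytometry and propidium iodide staining, with a stated time of 72 h; a higher number here means a weaker inhibitor, a lower number a stronger inhibitor. Here compound 1 `CC(=O)Nc1ccc2oc(-c3ccccc3)c(O)c(=O)c2c1` gives 36000 nM, compound 2 `COc1cccc(-c2oc3ccc(NC(C)=O)cc3c(=O)c2O)c1` gives 50000 nM and compound 3 `CC(=O)Nc1ccc2oc(-c3ccccc3F)c(O)c(=O)c2c1` gives 47000 nM. Compound 3 stands level with both others, with a 1.3-fold higher number from compound 1 to compound 3 (0.12 log units; within the scatter) and a 1.1-fold lower number from compound 2 to compound 3 (0.03 log units; within the scatter). The next compound, compound 4 `CC(=O)Nc1ccc2oc(-c3cccc(F)c3)c(O)c(=O)c2c1`, carries 3-fluorophenyl in place of 2-fluorophenyl on an aromatic carbon, next to the ring oxygen: 3-fluorophenyl in place of 2-fluorophenyl on an aromatic carbon. Among the compounds with values here, two measured steps bear on this: fluoro in place of hydrogen, a 1.3-fold higher number from compound 1 to compound 3 (0.12 log units; within the scatter), and methoxy in place of hydrogen, a 1.4-fold higher number from compound 1 to compound 2 (0.14 log units; within the scatter). Neither leaves the scatter, so no step beyond it is expected. The estimated step is a 1.0-fold lower number from compound 3 to compound 4 (0.02 log units; within the scatter). The expected value for compound 4 is 45000 nM, within an estimated range of 25000 nM to 80000 nM.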

Compound 4, half-maximal inhibitory concentration: 36000 nM
Compound 4: the middle estimate sits 1.3-fold (0.10 log units) above what was measured, within the range that was stated.
By their numbers in this assay, from the lowest: compounds 1, 4, 3 and 2 (each within the scatter of the next).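

In this assay, 3-fluorophenyl in place of 2-fluorophenyl gives a 1.3-fold lower number from compound 3 to compound 4 (0.12 log units; within the scatter), so the place of the fluoro on the phenyl ring does not separate these compounds. Fluoro in place of methoxy gives a 1.4-fold lower number from compound 2 to compound 4 (0.14 log units; within the scatter), and fluoro in place of hydrogen gives no change at the digits printed from compound 1 to compound 4 (within the scatter), so hydrogen, fluoro and methoxy on that ring all read alike here. No evidence is available to explain these readings. From the compounds shown here alone, whether an amine or a carboxylic acid on the phenyl ring would give a step beyond the scatter remains open.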